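Alkynyl aryl replacement at the pyridine-adjacent position

The source may report more compounds than this note shows. Statements on the series, on what has been measured and on what is new or still open speak of the compounds shown alone.

Compound 2 `CC(C(=O)NCc1ccc(C(F)(F)F)nc1-c1ccsc1)c1ccc(NS(C)(=O)=O)c(F)c1` — 2 nM
Compound 1 `CC(C(=O)NCc1ccc(C(F)(F)F)nc1-c1ccc(N(C)C)cc1)c1ccc(NS(C)(=O)=O)c(F)c1` — 3.2 nM

Compound 3 `CC(C(=O)NCc1ccc(C(F)(F)F)nc1C#Cc1ccccc1)c1ccc(NS(C)(=O)=O)c(F)c1` has not yet been measured. In an assay on CHO cells for antagonist activity at transient receptor potential cation channel subfamily V member 1 (Homo sapiens), read by FLIPR (on this read-out higher numbers stand for weaker inhibition and lower numbers for stronger inhibition), compound 2 gives 2 nM, the lowest of the two numbers shown, and compound 1 gives 3.2 nM, the nearest value; the one measured step, a 1.6-fold lower number from compound 1 to compound 2 (0.20 log units; within the scatter), stays within the scatter. Compound 3 carries 2-phenylethynyl in place of thiophen-3-yl on an aromatic carbon on the aromatic carbon next to the ring nitrogen. Going by the values given here, only that single step bears on this change, and it was small, so compound 3 is expected to show a 2.0-fold higher number from compound 2 to compound 3 (0.30 log units; within the scatter), with no clear direction beyond the scatter. Compound 3 is therefore estimated at 4 nM, within a range of 1 nM to 16 nM.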

Compound 3, inhibition constant: 0.8 nM
Compound 3: middle estimate off by 5.0-fold (0.70 log units), on the high side, and the stated range ends above it.
By their numbers in this assay, from the lowest: compound 3; then compounds 2 and 1 (each within the scatter of the next).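

In this assay, going by these compounds alone, the two aryl groups had stayed within the scatter of each other, while 2-phenylethynyl at this position gives the first steps beyond it, a 2.5-fold lower number from compound 2 to compound 3 (0.40 log units; beyond the scatter) and a 4.0-fold lower number from compound 1 to compound 3 (0.60 log units; beyond the scatter). Compound 3 is thus the strongest inhibitor of the three, and the position accepts a triple bond outside aromatic rings with a gain that is modest. Nothing available accounts for this gain. As far as these compounds go, it remains open whether the triple bond alone carries the gain, and how an ethynyl group ending in an amine, a hydroxymethyl group or a short alkyl chain would compare.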